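Swapping 4-hydroxyphenyl for 2,4-dichlorophenyl: compound 3 to compound 4

This account rests on a few compounds, and the source may have more. Where it says the series, first, only, none or still open, it means among the compounds named here.

In a functional assay on UACC-62 cells (Homo sapiens) (on this read-out higher numbers stand for weaker inhibition of growth and lower numbers for stronger inhibition of growth), compound 3 `O=S(=O)(/C=C/c1ccc(O)cc1)Cc1ccc(Nc2ncnc3ccc(Br)cc23)cc1` gives 28000 nM. This lies at the upper end of the three numbers available and within the scatter of compound 2 `O=S(=O)(/C=C/c1ccc(Cl)c(Cl)c1)Cc1ccc(Nc2ncnc3ccc(Br)cc23)cc1` at 30000 nM. Compound 1 `O=S(=O)(/C=C/c1ccc(Cl)cc1Cl)Cc1ccc(Nc2ncnc3ccccc23)cc1` gives 2000 nM, a number beyond the scatter from that of compound 3.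

Compound 4 `O=S(=O)(/C=C/c1ccc(Cl)cc1Cl)Cc1ccc(Nc2ncnc3ccc(Br)cc23)cc1` shares the core of compound 3 and differs from it at one place: 2,4-dichlorophenyl in place of 4-hydroxyphenyl on a double-bonded chain carbon bound to a double-bonded chain carbon. Among the measured compounds shown here, the only measured step at this place, a 1.1-fold lower number from compound 2 to compound 3 (0.03 log units; within the scatter), brings in 4-hydroxyphenyl where 3,4-dichlorophenyl stood, and it stays within the scatter. On this core, then, one exchange of these groups left this assay without a visible change.

For the measured compounds named here, compound 1 already carries 2,4-dichlorophenyl, but on a different core, and no measured step separates the effect of the group from that of the core. Its low number therefore allows only a slight lean downward. The expected result is no change beyond the scatter, with an estimated 1.6-fold lower number from compound 3 to compound 4 (0.19 log units; within the scatter).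

For compound 4 the estimated value is 18000 nM, with an expected range from 6000 nM to 45000 nM.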

Compound 4, concentration for 50% growth inhibition: 2000 nM
For compound 4 the middle estimate is 9.0-fold (0.95 log units) above the measured one; measured number outside the range, below it.
By their numbers in this assay, from the lowest: compounds 1 and 4 (each within the scatter of the next); then compounds 3 and 2 (each within the scatter of the next).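

In this assay, the place on a double-bonded chain carbon bound to a double-bonded chain carbon turned out to respond strongly on this core: 2,4-dichlorophenyl in place of 4-hydroxyphenyl gives a 14-fold lower number from compound 3 to compound 4 (1.15 log units; beyond the scatter), and 2,4-dichlorophenyl in place of 3,4-dichlorophenyl gives a 15-fold lower number from compound 2 to compound 4 (1.18 log units; beyond the scatter). The second step keeps the same atoms in the entering and leaving groups, so the change depends on which dichlorophenyl is present, not simply on having chlorine in the group, while bromo in place of hydrogen on an aromatic carbon gives no change at the digits printed from compound 1 to compound 4 (within the scatter), which ties the low numbers of both compounds to 2,4-dichlorophenyl and not to the bromo. Nothing given here explains why these two dichlorophenyl groups part so widely.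

The compounds shown leave open whether both chlorines of 2,4-dichlorophenyl are needed, or whether a 2-chlorophenyl or a 2,4-difluorophenyl would give a number as low. Also open is whether bromo and hydrogen stay level alongside 4-hydroxyphenyl or 3,4-dichlorophenyl, as the only such step shown carries 2,4-dichlorophenyl.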